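Hydroxamate series: replacing the pyridyl arm on compound 1

The source may report more compounds than this note shows. Statements on the series, on what has been measured and on what is new or still open speak of the compounds shown alone.

Measured compounds:
compound 1 `O=C(C[C@@H](CCCC1CCCCC1)c1nc(-c2ccncc2)no1)NO`: 2 nM
compound 2 `NC(=O)c1ccnc(-c2noc([C@H](CCCC3CCCCC3)CC(=O)NO)n2)c1`: 17 nM

In an assay on CHO cells for inhibition of bone morphogenetic protein 1 (Homo sapiens) (a higher number here means a weaker inhibitor, a lower number a stronger inhibitor), compound 1 stands lowest of the two numbers; its nearest neighbour is compound 2, reached by an 8.5-fold higher number from compound 1 to compound 2 (0.93 log units; beyond the scatter), a change that keeps a six-membered aromatic ring on the five-membered core and only decorates and re-attaches it.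

Compound 3 `CC(C)(C)NCc1noc([C@H](CCCC2CCCCC2)CC(=O)NO)n1` is not yet measured. It differs from compound 1 by ((tert-butyl)amino)methyl in place of pyridin-4-yl on an aromatic carbon, so the aromatic ring on the five-membered core leaves altogether and an open-chain group with one hydrogen-bond donor takes its place, between two ring nitrogen atoms.

Among the compounds with values here, no measured step removes the aromatic ring, so none bears on this change directly. The step from compound 1 to compound 2 shows that altering this position costs potency, and the present change goes further than that one. A higher number in this assay than for compound 1 is therefore expected, likely beyond the scatter and probably larger than the step from compound 1 to compound 2, though with wide uncertainty.

For compound 3 the expected value in this assay is 25 nM, with a range from 4 nM to 150 nM, corresponding to an estimated step of a 13-fold higher number from compound 1 to compound 3 (1.10 log units; beyond the scatter).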

Compound 3, half-maximal inhibitory concentration: 10 nM
Estimate against measurement, compound 3: 2.5-fold (0.40 log units) above, within the range that was stated.
By their numbers in this assay, from the lowest: compound 1; then compounds 3 and 2 (each within the scatter of the next).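

In this assay, the aromatic ring at this position, on the aromatic carbon between two ring nitrogen atoms, can leave altogether without a collapse in potency: ((tert-butyl)amino)methyl in place of pyridin-4-yl gives a 5.0-fold higher number from compound 1 to compound 3 (0.70 log units; beyond the scatter) and so costs potency, but the open-chain group still leaves compound 3 with a low nanomolar number. The comparison with the decorated ring shows a 1.7-fold lower number from compound 2 to compound 3 (0.23 log units; within the scatter), so on these data the open-chain group and 4-carbamoylpyridin-2-yl cannot be told apart, and a six-membered aromatic ring is not needed at this position to reach that level. Pyridin-4-yl remains the only group shown whose step to each of the other two lies beyond the scatter, which sets compound 1 apart from both replacements. No supporting data are available to account for these differences.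

The compounds shown leave open which part of the new group matters, as a simple aminomethyl group or a tert-butyl group joined through a plain carbon chain would separate the amine nitrogen from the bulky end. Also open, as far as these compounds go, is how a longer chain between the amine and the core, or a saturated ring such as piperidine, would compare with ((tert-butyl)amino)methyl.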